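Furan-2-yl on the sulfonyl sulfur: what to expect

The source may hold more compounds than are shown below. What is called first, only, known or untested is meant among the compounds shown, and "the series" means these compounds.

Measured compounds:
compound 1 `CNCc1cc(-c2ccccc2)n(S(=O)(=O)c2ccccc2)c1`: 96%
compound 2 `CNCc1cc(-c2cccnc2F)n(S(=O)(=O)c2cccc(OC)c2)c1`: 92%

For the measured compounds named here, the two measured compounds share a core that differs between them at two places, so no single step between them is set out here. In a functional assay on the whole organism (strain Jcl:SD) for inhibition, with Rattus norvegicus as the target, with stated times of 3 min and 3 h, at a dose of 1 mg/kg by the intravenous route (on this read-out higher numbers stand for more inhibition at the one dose given (going by the name of the read-out) and lower numbers for less inhibition), compound 1 gives 96% and compound 2 gives 92%; the two numbers lie within the scatter of each other, so neither can be called the stronger. Compound 2 has the lower of the two numbers, with compound 1 a few points higher, a gap that means nothing on its own.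

Compound 3 `CNCc1cc(-c2cccnc2F)n(S(=O)(=O)c2ccco2)c1` has not been measured in this assay. It differs from compound 2 in one place: furan-2-yl in place of 3-methoxyphenyl on a sulfonyl sulfur. Going by the values given here, no measured pair tells how this change plays out, so the expectation rests only on the high number of compound 2.

Compound 3 is expected to stay near compound 2, with any step from compound 2 to compound 3 estimated to be small, a number 7 percentage points lower from compound 2 to compound 3 (within the scatter), and not clearly beyond the scatter. The estimate for compound 3 is 85%, between 60% and 97%.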

Compound 3, a percentage reported as inhibition, in the whole organism at one dose (the size of the read-out at that dose, not a potency): 74%
Compound 3: the middle estimate sits 11 percentage points above what was measured; the range from low to high includes it.
By their numbers in this assay, from the lowest: compound 3; then compounds 2 and 1 (each within the scatter of the next).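

Furan-2-yl in place of 3-methoxyphenyl on the sulfonyl sulfur is the first single change that can be read in this assay, and it gives a number 18 percentage points lower from compound 2 to compound 3 (beyond the scatter) as a modest step beyond the scatter. The two earlier compounds differ at two places and lie within the scatter of each other, so they could not show that this position responds to the group it carries, and that high inhibition at the one dose given does not survive every replacement there. Nothing measured here accounts for the step.

As far as these compounds go, with only this one replacement, it stays open whether the step belongs to the furan-2-yl as such, or whether other groups on the sulfonyl sulfur, such as thiophen-2-yl, a plain methyl or a longer alkyl chain, would fall with it or stay close to compound 2. From the compounds shown here alone, it also stays open whether the same change would give a step of similar size in a compound that carries phenyl in place of the fluorinated ring of compound 2.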